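The compounds below may be only part of what the source reports. "The series", "measured", "known", "first", "only" and "open" are said of these compounds alone.

- Compound 1 `CC(=O)Nc1ccc(S(=O)(=O)Nc2cc(SCC(=O)N[C@@H](CC(C)C)B(O)O)c(O)c3ccccc23)cc1`: 8660 nM
- Compound 2 `CC(C)C[C@H](NC(=O)CCSc1cc(NS(=O)(=O)c2ccccc2)c2ccccc2c1O)B(O)O`: 7460 nM

Both values come from a functional assay on MCF7 cells (Homo sapiens) for antiproliferative activity, read by sulforhodamine B assay, with a stated time of 72 h; a lower number here means a stronger inhibitor, a higher number a weaker inhibitor. Compound 2, at 7460 nM, lies within the usual scatter of compound 1, at 8660 nM, so the two cannot be ranked against each other. Their structures differ in more than one place, so this pair cannot show what any single change does.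

Compound 3 `CC(C)C[C@H](NC(=O)CCSc1cc(NS(=O)(=O)c2cccs2)c2ccccc2c1O)B(O)O` keeps the rest of compound 2 and carries thiophen-2-yl in place of phenyl on a sulfonyl sulfur. For the measured compounds named here, one aromatic ring is exchanged for another, and nothing measured so far tests this change directly. The expectation therefore rests on the value of compound 2, 7460 nM, and no shift beyond the scatter is expected in this assay, in either direction. The expected change is a 1.1-fold lower number from compound 2 to compound 3 (0.03 log units; within the scatter), an estimate that stays within the scatter. In this assay, compound 3 is estimated at 7000 nM, with an expected range from 3000 nM to 16000 nM.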

Compound 3, half-maximal inhibitory concentration: 6470 nM
Estimate against measurement, compound 3: 1.1-fold (0.03 log units) above; measured number inside the range.
By their numbers in this assay, from the lowest: compounds 3, 2 and 1 (each within the scatter of the next).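

For the compounds shown here, compound 2 and compound 3 differ in one place only, the group on the sulfonyl sulfur, so this is the first pair here that isolates a single change. With thiophen-2-yl in place of phenyl, the step (a 1.2-fold lower number from compound 2 to compound 3 (0.06 log units; within the scatter)) in this assay does not separate the two compounds, so at this position a five-membered aromatic ring with one sulfur and a six-membered aromatic ring of carbon only cannot be told apart in this read-out. No measurement of any property of these two groups accompanies this result, and it offers no explanation for what is seen.

Going by these compounds, both groups compared here are unsubstituted aromatic rings, so it remains open how a cyclohexyl group, a short alkyl chain, or an aromatic ring carrying an amine or a carboxylic acid would behave on the sulfonyl sulfur. On these data alone, it is also open whether the same exchange of phenyl for thiophen-2-yl would give a similar reading on the scaffold of compound 1, whose other differences from compound 2 remain unseparated.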